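The compounds below may be only part of what the source reports. "The series", "measured", "known", "first", "only" and "open" are said of these compounds alone.

In an ADME assay on S9 fraction from liver (Mus musculus) for metabolic stability, read by LC-MS, using NADPH, with a stated time of 45 min, tested at 3 uM, in the presence of a further agent that is not named here (a lower number here means that the liver removes a smaller share, a higher number that the liver removes a larger share of the compound in one pass), compound 1, `COc1ccc(-n2cnc3cnc(-c4ccc(F)cc4C)cc32)cc1`, gives 1, so the liver removes essentially the whole of it in one pass. Compound 2, `Fc1ccc(-c2cc3c(cn2)ncn3-c2ccc(OC(F)F)cc2)cc1`, shares that core but carries a difluoromethoxy group in place of the methoxy and lacks the methyl on the fluorophenyl; in this assay compound 2 gives "not determined" (no result reported), so no number stands for it. Compound 3, `COc1cc(F)ccc1-c1cc2c(cn1)ncn2-c1ccc(OC(F)F)cc1`, differs from compound 2 by methoxy in place of hydrogen on an aromatic carbon. Without a step between measured compounds, no direction for this change can be read from the data, and the only point of reference is the complete removal of compound 1. Compound 3 is therefore expected to show a high extraction ratio of about 0.9, with a plausible range from 0.7 to 1, since the one measured relative leaves little room for a further rise and any fall would need a cause the data do not show.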

Compound 3, hepatic extraction ratio: 0.21
Compound 3: middle estimate off by 0.69, on the high side; measured number outside the range, below it.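

In this assay, within the data shown here, compound 2 gives "not determined" (no result reported), so no step to compound 3 can be read. The compounds shown leave open what the change from 4-fluorophenyl to 4-fluoro-2-methoxyphenyl does to the hepatic extraction ratio. Nothing shown bears on the cause of the result.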